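Chloro in Place of Fluoro: Expectation for Compound 4

The compounds below may be only part of what the source reports. "The series", "measured", "known", "first", "only" and "open" are said of these compounds alone.

Measured compounds:
compound 1, `C/C(=C\c1cc(-c2ccc(C)nc2)co1)C(N)=O` — in a functional assay on BGC-823 cells (Homo sapiens) for cytotoxicity, read by CCK-8 assay, with a stated time of 24 h (on this read-out lower numbers stand for stronger inhibition and higher numbers for weaker inhibition), compound 1 gives > 50000 nM, which is a limit of the assay.
compound 2, `C/C(=C\c1cc(-c2ccc(F)cc2)cs1)C(N)=O` — in this assay compound 2 gives > 50000 nM, also a limit of the assay.
compound 3, `C/C(=C\c1nc(-c2ccccc2)cs1)C(N)=O` — in this assay compound 3 gives > 50000 nM, again a limit of the assay.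

Compound 2 thus stands nowhere in particular among these numbers: its own result is a limit, and the two other values shown are limits as well, so all three sit at the limit of > 50000 nM in this assay, at which 3 of the 3 values shown sit, and no order among them can be read. Going by the values given here, no two of the measured compounds differ in a single place, so there is no measured step to lean on.

Compound 4, `C/C(=C\c1cc(-c2ccc(Cl)cc2)cs1)C(N)=O`, differs from compound 2 by chloro in place of fluoro on an aromatic carbon; the change sits on an aromatic carbon of a six-membered aromatic ring of carbon only, para to a large group. With the three measured values all at the limit, compound 4 is expected to show no step beyond the usual scatter, so the step of a number no higher from compound 2 to compound 4 (the limit leaves the size open) is estimated to be essentially nil. Compound 4 is therefore expected to come out around 50000 nM, within a range of 20000 nM to 120000 nM, most likely reported only as a limit.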

Compound 4, half-maximal inhibitory concentration: > 50000 nM
Compound 4 ended at the assay's limit (the forecaster's own chance of this, stated with the estimate: 85%); the middle value lies on the limit itself.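

No step can be read from compound 2 to compound 4, the change of chloro in place of fluoro, since both compounds end at the same limit: the limit of > 50000 nM in this assay, at which 4 of the 4 values shown sit. The compounds shown leave open how far each lies beyond that limit, and whether chloro and fluoro differ at all on this read-out.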